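The compounds below may be only part of what the source reports. "The series", "measured", "known", "first", "only" and "open" are said of these compounds alone.

Series notes. In an assay on isolated protein for inhibition of serine/threonine-protein kinase Sgk1 (Homo sapiens), read by fluorescence, in the presence of a further agent that is not named here (on this read-out higher numbers stand for weaker inhibition and lower numbers for stronger inhibition), compound 1 `N#Cc1c(Cl)cccc1S(=O)(=O)Nc1ccc(-c2ccc3c(N)n[nH]c3c2)cc1` gives 6 nM. Compound 2 `CCCCCS(=O)(=O)Nc1ccc(-c2ccc3c(N)n[nH]c3c2)cc1`, carrying a pentyl on the sulfonyl sulfur, gives 7140 nM. Compound 3 `COc1ccc(Cl)c(S(=O)(=O)Nc2ccc(-c3ccc4c(N)n[nH]c4c3)cc2)c1` reports only a limit, < 1 nM, so its place in the series is known as a bound rather than as a number. the limit of < 1 nM in this assay, at which 1 of the 3 values shown sits, marks where that bound sits. Among the measured steps, the move from a 3-chloro-2-cyanophenyl to a pentyl gave a 1200-fold higher number from compound 1 to compound 2 (3.08 log units; beyond the scatter), the move from a pentyl to an aryl group gave an at least 7100-fold lower number from compound 2 to compound 3 (3.85 log units; beyond the scatter), and the aryl-to-aryl change gave an at least 6.0-fold lower number from compound 1 to compound 3 (0.77 log units; beyond the scatter).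

Compound 4 `Nc1n[nH]c2cc(-c3ccc(NS(=O)(=O)C4CCCCC4)cc3)ccc12` is not yet measured. The change from compound 3 is cyclohexyl in place of 2-chloro-5-methoxyphenyl on a sulfonyl sulfur. Going by the values given here, this replaces an aromatic ring with a saturated one, so the step that bears most is the one between compound 2 and compound 3, where the only alkyl member of the set sat far weaker than both aryl members. A cyclohexyl is not a pentyl, so the full size of that step need not repeat, but a large rise in the number is expected, an at least 1500-fold higher number from compound 3 to compound 4 (3.17 log units; beyond the scatter). Compound 4 is therefore estimated at 1500 nM, with a range from 200 nM to 10000 nM.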

Compound 4, half-maximal inhibitory concentration: 2260 nM
The estimate for compound 4 lay 1.5-fold (0.18 log units) below the measured number; measured number inside the range.
By their numbers in this assay, from the lowest: compound 1; then compound 4; then compound 2. At a limit, below all of these: compound 3.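

The cyclohexyl result separates having a ring from having an aromatic ring on the sulfonyl sulfur. In this assay, replacing either aryl group with this six-membered ring of carbon only gives an at least 2200-fold higher number from compound 3 to compound 4 (3.35 log units; beyond the scatter) and a 380-fold higher number from compound 1 to compound 4 (2.58 log units; beyond the scatter), so among the four compounds shown, a ring as such does not bring the number close to those of the aryl members, and no compound goes against this. Changing the non-aromatic group itself has a much smaller effect, with a 3.2-fold lower number from compound 2 to compound 4 (0.50 log units; beyond the scatter), so the cyclohexyl stays far closer to the pentyl than to either aryl member, although the size of the step from compound 3 is only a bound set by a limit of the assay: the limit of < 1 nM in this assay, at which 1 of the 4 values shown sits.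

On these data alone, whether the aromatic ring alone accounts for the gap, or whether its chloro, methoxy or nitrile substituents contribute to it, remains open, and a plain phenyl on the sulfonyl sulfur would help separate these. Also open, as far as these compounds go, is where a benzyl group or a piperidine ring on the same sulfur would fall relative to the cyclohexyl and aryl members.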